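The source may report more compounds than this note shows. Statements on the series, on what has been measured and on what is new or still open speak of the compounds shown alone.

Measured compounds:
- compound 1, `Cc1ccccc1-n1nc(C)c2c1NC(=O)[C@H](C)S[C@@H]2c1ccc(-c2cccc(C(=O)O)c2)cc1`: "not active" (no number reported) in an assay on isolated protein for agonist activity at Bile acid receptor (Homo sapiens), read by AlphaScreen, with a stated time of 30 min; on this read-out lower numbers stand for an effect already at smaller amounts and higher numbers for an effect only at larger amounts of compound
- compound 2, `Cc1nn(-c2ccccc2Cl)c2c1C(c1ccc(Oc3ccccc3)cc1)SC(C)C(=O)N2`: 2700 nM

Compound 1 stands without a single number in this assay: the record gives it only as not active, so no half-maximal effective concentration can be placed for it on the scale. Within the data shown here, compound 2 shares the core with compound 1 but differs from it in more than one place; the value of compound 2, 2700 nM, can therefore only be read on its own as the one numerical point, and no step from compound 1 to compound 2 can be set against the scatter.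

Compound 3, `Cc1ccccc1-n1nc(C)c2c1NC(=O)[C@H](C)S[C@@H]2c1ccc(/C=C/c2ccccc2)cc1`, has not been measured. It differs from compound 1 by 2-phenylethenyl in place of 3-carboxyphenyl on an aromatic carbon. Among the measured compounds shown here, no measured pair isolates this change, so the size and direction of the step from compound 1 to compound 3 cannot be read from the series. Given that compound 1 gave no number at all, the step is expected to stay on the weak side, with a real chance that compound 3 also reports only a limit. Compound 3 is estimated at 6000 nM, within a range from 1200 nM to 30000 nM.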

Compound 3, half-maximal effective concentration: "not active" (no number reported)
No number was reported for compound 3, and the estimate cannot be compared.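

Among these compounds, compound 1 and compound 3 both stand without a number in this assay, so no step between them can be read. No measured information bears on this result. The compounds shown leave open whether 2-phenylethenyl in place of 3-carboxyphenyl shifts the read-out at all, and which single change on the shared core separates these two from compound 2 at 2700 nM.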